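A few compounds are considered here, and "the series" means these few. Any claim that something is new, unique, unknown or untested is made for them only; others in the source may bear on it.

Compound 1 `Nc1scc(CN2CCN(c3cccc(C(F)(F)F)c3)CC2)c1C(=O)c1ccc(Cl)cc1` shows no measurable displacement in an assay on CHO cells for displacement of a labelled ligand from adenosine receptor A1 (Homo sapiens), read by scintillation counting, with a stated time of 120 min, tested at 10 uM; a higher number here means more inhibition at the concentration tested (going by the name of the read-out), a lower number less inhibition: compound 1 gives 0%. Two companions share its core and differ only in the group on an amine nitrogen in a ring. Compound 2 `Nc1scc(CN2CCN(c3cccc(F)c3F)CC2)c1C(=O)c1ccc(Cl)cc1` gives 0% and compound 3 `Nc1scc(CN2CCN(CCCc3ccc(Cl)cc3)CC2)c1C(=O)c1ccc(Cl)cc1` gives 0%, so compound 1 stands level with both, with compound 2 nearest and compound 3 furthest only nominally. The steps of no change at the digits printed from compound 1 to compound 2 (within the scatter) and no change at the digits printed from compound 1 to compound 3 (within the scatter) show that changing this group has so far left the read-out flat. Compound 4 `Nc1scc(CN2CCN(c3ccc(Cl)c(Cl)c3)CC2)c1C(=O)c1ccc(Cl)cc1` is another such variation: 3,4-dichlorophenyl in place of 3-(trifluoromethyl)phenyl on an amine nitrogen in a ring. Since the comparable steps were flat, the expected step is no change at the digits printed from compound 1 to compound 4 (within the scatter), none beyond the scatter. Compound 4 is therefore estimated to give 0%, within -5% to 10%.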

Compound 4, a percentage reported as inhibition, at one concentration (the size of the read-out at that concentration, not a potency): 1%
The estimate for compound 4 lay 1 percentage points below the measured number; measured number inside the range.
By their numbers in this assay, from the lowest: compounds 1, 2, 3 and 4 (each within the scatter of the next).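

In this assay, 3,4-dichlorophenyl on this amine nitrogen gives only small steps (a number 1 percentage points higher from compound 1 to compound 4 (within the scatter) and a number 1 percentage points higher from compound 2 to compound 4 (within the scatter) and a number 1 percentage points higher from compound 3 to compound 4 (within the scatter)). The flat read-out at this position therefore now extends to a phenyl ring carrying two chlorine atoms, alongside the trifluoromethyl, difluoro and chlorophenylpropyl groups. Nothing available gives a reason for this. Still open, from the compounds shown here alone, is whether a hydroxyl, an amine or a carboxylic acid on the phenyl ring would lift the read-out above this flat level.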